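Two compounds level, a third awaiting measurement

The compounds below may be only part of what the source reports. "The series", "measured", "known", "first", "only" and "open" are said of these compounds alone.

Compound 1 `COc1cc(C2SCC(=O)N2c2nnc(CNn3c(C)nc4ccc(Br)cc4c3=O)s2)ccc1O` and compound 2 `COc1ccc(C2SCC(=O)N2c2nnc(CNn3c(C)nc4ccccc4c3=O)s2)cc1` share a common core and were both tested in a functional assay on the whole organism (strain albino) with Rattus norvegicus as the target, in the maximal electroshock model, with a stated time of 1 h, at a dose of 30 mg/kg by the intraperitoneal route; a higher number here means more inhibition at the dose given (going by the name of the read-out), a lower number less inhibition. In this assay compound 1 gives 60%, and compound 2 gives 60% in this assay, so the two values stand level at the digits shown and within the usual scatter of the measurement. Compound 2 thus sits at the same level as its nearest measured neighbour, compound 1, with no order between them.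

Compound 3 `COc1cc(C2SCC(=O)N2c2nnc(CNn3c(C)nc4ccccc4c3=O)s2)ccc1O` has not yet been measured in this assay. It differs from compound 2 in one place: 4-hydroxy-3-methoxyphenyl in place of 4-methoxyphenyl on a saturated ring carbon. Compound 1 already carries the 4-hydroxy-3-methoxyphenyl group and gives 60% in this assay. The expected step in this assay is no change at the digits printed from compound 2 to compound 3 (within the scatter), not beyond the scatter. Compound 3 is therefore estimated to give 60% in this assay, with an expected range from 45% to 75%.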

Compound 3, a percentage reported as inhibition, in the whole organism at one dose (the size of the read-out at that dose, not a potency): 60%
For compound 3 middle estimate and measured number coincide at the digits printed, and the stated range covers the measured number.
By their numbers in this assay, from the lowest: compounds 1, 2 and 3 (each within the scatter of the next).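

In this assay, going by these compounds alone, 4-hydroxy-3-methoxyphenyl in place of 4-methoxyphenyl on a saturated ring carbon gives no change at the digits printed from compound 2 to compound 3 (within the scatter), the first reading of a change at this position alone, since compound 1 and compound 2 differ in more than one place. Hydrogen in place of bromo on an aromatic carbon likewise gives no change at the digits printed from compound 1 to compound 3 (within the scatter), so at this single dose neither change separates the compounds, and compound 3 links the two earlier compounds by single steps. Nothing measured here offers an explanation for these results.

Still open, from the compounds shown here alone, is whether any group at either place moves the read-out beyond the scatter, for example an amine in place of the aryl group on the saturated ring carbon. A single dose also leaves any difference in potency among these compounds unresolved.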